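Hydroxy to Fluoro: Expected Effect on Cell Tolerance

The source may report more compounds than this note shows. Statements on the series, on what has been measured and on what is new or still open speak of the compounds shown alone.

Of the compounds shown here, three built on one shared core have been tested for how much of each cultured cells can tolerate. Compound 1 `O=C(COc1cccc2ccccc12)N/N=C/c1ccc(O)cc1` carries a hydroxy group on its outer ring, and in an ADME assay on MT4 cells (Homo sapiens) for cytotoxicity, read by MTT assay, with a stated time of 4 days (a lower number here means that less compound is tolerated, a higher number that more compound is tolerated), compound 1 gives 26.5 ug/mL. Compound 2 `C/C(=N\NC(=O)COc1cccc2ccccc12)c1ccc(O)cc1O` has a more heavily substituted outer ring, and in this assay compound 2 gives 59.9 ug/mL. Compound 3 `COc1cc(/C=N/NC(=O)COc2cccc3ccccc23)cc(OC)c1O`, with two methoxy groups flanking its hydroxy, gives 16.3 ug/mL in this assay.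

On these numbers compound 1 stands second highest of the three. Its gap to compound 3 lies within the usual scatter of the method, so the two cannot be ranked against each other. Its gap to compound 2 lies beyond that scatter, so more of compound 2 is tolerated than of compound 1.

Compound 4 `O=C(COc1cccc2ccccc12)N/N=C/c1ccc(F)cc1` differs from compound 1 in a single place: fluoro in place of hydroxy on an aromatic carbon. Among the measured compounds shown here, no measured pair shows this swap, so there is no precedent for its size. The expectation is a small step, from compound 1 to compound 4 of a 1.3-fold lower number from compound 1 to compound 4 (0.12 log units; within the scatter), towards a somewhat lower number but possibly none beyond the scatter. Compound 4 is therefore estimated at 20 ug/mL, within a range from 8 ug/mL to 50 ug/mL.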

Compound 4, half-maximal cytotoxic concentration: 65.1 ug/mL
Compound 4: middle estimate off by 3.3-fold (0.51 log units), on the low side; measured number above the stated range.
By their numbers in this assay, from the lowest: compounds 3 and 1 (each within the scatter of the next); then compounds 2 and 4 (each within the scatter of the next).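

Swapping hydroxy for fluoro on this aromatic carbon, para to a large group, gives a clear change in this assay: a 2.5-fold higher number from compound 1 to compound 4 (0.39 log units; beyond the scatter). This pair is the first among the compounds shown to differ in one place only, so it gives the first direct reading of this position: the step lies beyond the usual scatter, and more of compound 4 is tolerated than of compound 1. The swap removes a hydrogen-bond donor and a hydrogen-bond acceptor, but nothing measured here links the step to that loss or to any other property of either group.

On these data alone, it remains open whether the step comes from having fluoro at this position or simply from losing hydroxy, a question that plain hydrogen, chloro or an amine at the same place could help to settle. As far as these compounds go, it is also open whether the same swap would give a step of similar size on the outer rings of compound 2 and compound 3, which carry further groups.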